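One methoxy more on the core of compound 1

The source may hold more compounds than are shown below. What is called first, only, known or untested is meant among the compounds shown, and "the series" means these compounds.

In a physicochemical assay for solubility, read by chemiluminescence, measured as kinetic solubility (a lower number here means a less soluble compound, a higher number a more soluble compound), compound 1 (`COc1nn(C)c2ncnc(NS(=O)(=O)c3cccc(Cl)c3Cl)c12`) gives >= 581000 nM as a limit of the assay. Compound 2 (`COc1nn(CC(=O)O)c2ncnc(NS(=O)(=O)c3cccc(Cl)c3Cl)c12`) likewise gives only a limit, >= 483000 nM in this case. Within the data shown here, the one measured step, a step that the two limits leave unreadable from compound 1 to compound 2 here, offers no size to build on. Compound 3 (`COc1nc(NS(=O)(=O)c2cccc(Cl)c2Cl)c2c(OC)nn(C)c2n1`) has methoxy in place of hydrogen on an aromatic carbon, between two ring nitrogen atoms (methoxy in place of hydrogen on an aromatic carbon). With no readable guide, no change beyond the scatter is expected, and the estimated step of an at least 1.2-fold lower number from compound 1 to compound 3 (0.11 log units; that floor lies within the scatter) has no firm direction. In this assay compound 3 is expected at 450000 nM with an estimated range from 200000 nM to 650000 nM for now.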

Compound 3, solubility: 148000 nM
Beside the measured number, compound 3's estimate is 3.0-fold (0.48 log units) above it; the whole stated range lies above it.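

Among these compounds, putting methoxy in place of hydrogen on this aromatic carbon, between two ring nitrogen atoms, gives in this assay an at least 3.9-fold lower number from compound 1 to compound 3 (0.59 log units; beyond the scatter) and so provides the first step here with a readable direction. The other step, to compound 2, cannot be read. This size is only a floor, because compound 1 stands at a limit of the assay: the limit of >= 581000 nM in this assay, at which 1 of the 3 values shown sits.

From the compounds shown here alone, it remains open whether the lower number belongs to methoxy itself or would follow other groups at this position. An amine or a longer chain such as ethoxy there could separate those two readings.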